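The source may report more compounds than this note shows. Statements on the series, on what has been measured and on what is new or still open speak of the compounds shown alone.

Compound 1 `CCC1=C(O)c2c(oc(-c3ccc(C(C)C)cc3)cc2=O)C(CC)(CC)C1=O`: 1.08 uM
Compound 2 `CCC1=C(O)c2c(oc(-c3cccc(OC)c3)cc2=O)C(CC)(CC)C1=O`: 1.22 uM

In a functional assay on KBVIN cells (Homo sapiens) for antiproliferative activity, read by sulforhodamine B assay, with a stated time of 3 days (a higher number here means that more compound is needed for the effect, a lower number that less compound is needed), compound 2 gives 1.22 uM, within the scatter of compound 1 at 1.08 uM. Compound 3 `CCC1=C(O)c2c(oc(-c3ccc(OC)c(OC)c3)cc2=O)C(CC)(CC)C1=O` differs from compound 2 as follows: methoxy in place of hydrogen on an aromatic carbon. This places methoxy in place of hydrogen on an aromatic carbon, ortho to a methoxy group and para to a large group. Going by the values given here, only one measured step bears on this change: a 1.1-fold higher number from compound 1 to compound 2 (0.05 log units; within the scatter). It exchanged 4-isopropylphenyl for 3-methoxyphenyl and stayed within the scatter. Among the compounds with values here, no measured compound carries the added methoxy, so the data give no direction, and no step beyond the scatter is expected. The expected step is a 1.1-fold higher number from compound 2 to compound 3 (0.03 log units; within the scatter). For compound 3 the estimated value is 1.3 uM, with an expected range of 0.5 uM to 3.5 uM.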

Compound 3, concentration for half-maximal effect: 1 uM
For compound 3 the middle estimate is 1.3-fold (0.11 log units) above the measured one, within the range that was stated.
By their numbers in this assay, from the lowest: compounds 3, 1 and 2 (each within the scatter of the next).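

In this assay, methoxy in place of hydrogen on an aromatic carbon, ortho to a methoxy group and para to a large group, gives a 1.2-fold lower number from compound 2 to compound 3 (0.09 log units; within the scatter). Compared with the earlier exchange of one substituted phenyl for another, this step shows that adding a group at this position, with one methoxy already present, leaves the number within the scatter. Nothing available on this series accounts for that outcome.

From the compounds shown here alone, whether an amine, a carboxylic acid or a longer alkoxy chain at this position would also stay within the scatter remains open. Changes to the shared core also remain open, as compound 1, compound 2 and compound 3 differ only in the aromatic group attached to it.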